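Aromatic to saturated ring on the ether oxygen

A few compounds are considered here, and "the series" means these few. Any claim that something is new, unique, unknown or untested is made for them only; others in the source may bear on it.

In a functional assay on MX1 cells (Homo sapiens) for antiproliferative activity, with a stated time of 72 h (on this read-out higher numbers stand for an effect only at larger amounts of compound and lower numbers for an effect already at smaller amounts), compound 1 `Cc1cc(-c2ccccc2Oc2ccccc2)c[nH]c1=O` gives 2400 nM while compound 2 `CCS(=O)(=O)Nc1ccc(Oc2ccc(C#N)cc2)c(-c2cn(C)c(=O)c3[nH]ccc23)c1` gives 17 nM and compound 3 `Cn1cc(-c2cc(NS(C)(=O)=O)ccc2Oc2ccc(F)cc2Cl)c2cc[nH]c2c1=O` gives 27 nM in the same read-out. Compound 3 lies within the scatter of compound 2 and far below compound 1, a gap well beyond the scatter.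

Compound 4 `Cn1cc(-c2cc(NS(C)(=O)=O)ccc2OC2CCC(F)(F)CC2)c2cc[nH]c2c1=O` carries 4,4-difluorocyclohexyl in place of 2-chloro-4-fluorophenyl on an oxygen on an aromatic ring, counted as 4,4-difluorocyclohexyl in place of 2-chloro-4-fluorophenyl on an oxygen on an aromatic ring for this step. Among the measured compounds shown here, no measured pair isolates this change. On these data alone, all three measured compounds keep an aromatic ring on that oxygen, so a non-aromatic ring there is untested and the expectation carries wide uncertainty. In this assay a moderately higher number is expected for the non-aromatic ring, with a result inside the scatter still possible. The step expected is a 2.6-fold higher number from compound 3 to compound 4 (0.41 log units; beyond the scatter) and it remains only an estimate. Compound 4 is estimated at 70 nM with a range from 20 nM to 250 nM in this read-out.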

Compound 4, half-maximal effective concentration: 19 nM
Beside the measured number, compound 4's estimate is 3.7-fold (0.57 log units) above it, and the stated range ends above it.
By their numbers in this assay, from the lowest: compounds 2, 4 and 3 (each within the scatter of the next); then compound 1.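

In this assay, 4,4-difluorocyclohexyl in place of 2-chloro-4-fluorophenyl on an oxygen on an aromatic ring gives a 1.4-fold lower number from compound 3 to compound 4 (0.15 log units; within the scatter). Among the compounds shown here, this is the first pair to isolate this change, and it shows that an aromatic ring at this place is not required to keep the number within the scatter: a six-membered non-aromatic ring of carbon only serves there, with the chlorine gone and a second fluorine present. Nothing available bears on why the two rings read alike.

Still open, on these data alone, is how plain cyclohexyl, a cyclohexyl ring carrying an amine or a carboxylic acid, or an open butyl chain would read on that oxygen. As far as these compounds go, the finding also rests on a single pair, so whether it carries over to the ethylsulfonyl amide of compound 2 remains open.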